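Dichlorophenyl swap on the methoxyphenyl series

A few compounds are considered here, and "the series" means these few. Any claim that something is new, unique, unknown or untested is made for them only; others in the source may bear on it.

Three compounds of one shared core have been run through a functional assay on HeLa cells (Homo sapiens) for cytotoxicity, read by CCK-8 assay, with a stated time of 72 h; on this read-out higher numbers stand for weaker inhibition and lower numbers for stronger inhibition. Among the measured compounds shown here, compound 1 `C=CCn1c(=O)/c(=C\c2cccc(C)c2)[nH]c(=O)/c1=C\c1ccccc1OC` is the only member with a number: in this assay compound 1 gives 19300 nM. Compound 2 `C=CCn1c(=O)/c(=C\c2ccc(Cl)c(Cl)c2)[nH]c(=O)/c1=C\c1ccccc1` carries the 3,4-dichlorophenyl group and an unsubstituted phenyl; in this assay compound 2 is reported as "not active" (no number reported), with no number behind it. Compound 3 `C=CCn1c(=O)/c(=C\c2ccc(C)cc2)[nH]c(=O)/c1=C\c1ccccc1OC` stands in the same position: in this assay compound 3 is reported as "not active" (no number reported), so it has no single number, and one further entry in the set shares that status. For the measured compounds named here, no pair of measured compounds differs in one place, so no measured step exists to lean on.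

Compound 4 `C=CCn1c(=O)/c(=C\c2ccc(Cl)c(Cl)c2)[nH]c(=O)/c1=C\c1ccccc1OC` is the untested member. Against compound 3 the change is 3,4-dichlorophenyl in place of 4-methylphenyl on a double-bonded chain carbon bound to an aromatic carbon. The 3,4-dichlorophenyl group already appears in compound 2, which gave no number, and the 2-methoxyphenyl side is kept from compound 3, which also gave no number. In this assay no step beyond the scatter is expected in either direction; compound 4 is expected to remain weak, likely without a number. The estimate for compound 4 is 40000 nM, within 15000 nM to 120000 nM, with a high chance that only a limit is reported.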

Compound 4, half-maximal inhibitory concentration: "not active" (no number reported)
Compound 4: no number reported, and the estimate cannot be compared.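

In this assay compound 4, like compound 3, has no number, so no step can be read for 3,4-dichlorophenyl in place of 4-methylphenyl. The compounds shown leave open how compound 2, compound 3 and compound 4 compare with compound 1 on this read-out. No measured evidence bears on this result.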